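Hydroxycyclohexyl amine variants on the cyanopyridine core

The source may hold more compounds than are shown below. What is called first, only, known or untested is meant among the compounds shown, and "the series" means these compounds.

Measured compounds:
- compound 1, `N#Cc1cnc(NCc2cnccc2C(F)(F)F)cc1N[C@H]1CC[C@H](O)CC1`: 350 nM
- compound 2, `N#Cc1cnc(NCc2cnccc2C(F)(F)F)cc1NC[C@H]1CC[C@H](O)CC1`: 50 nM
- compound 3, `N#Cc1cnc(NCc2cnccc2C(F)(F)F)cc1N[C@H]1CC[C@@H](C(N)=O)CC1`: 7 nM

All three share the core of compound 1 and differ only in the group on a nitrogen on an aromatic ring. In an assay on isolated protein for inhibition of protein kinase C theta type (Homo sapiens), read by TR-FRET, with a stated time of 2 h (a lower number here means a stronger inhibitor, a higher number a weaker inhibitor), compound 3 holds the lowest number of the three: a 7.1-fold lower number from compound 2 to compound 3 (0.85 log units; beyond the scatter) and a 50-fold lower number from compound 1 to compound 3 (1.70 log units; beyond the scatter), both beyond the scatter. The other step, a 7.0-fold lower number from compound 1 to compound 2 (0.85 log units; beyond the scatter), is modest.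

Compound 4, `CC1(C)C[C@@H](Nc2cc(NCc3cnccc3C(F)(F)F)ncc2C#N)CC[C@@H]1O`, carries 4-hydroxy-3,3-dimethylcyclohexyl in place of 4-carbamoylcyclohexyl on a nitrogen on an aromatic ring. The step from compound 1 to compound 3 is the closest measured comparison, as it exchanges a hydroxyl-bearing ring for the carbamoyl-bearing one; compound 4 runs that exchange the other way, so the hydroxyl of compound 1 is restored, now with two methyl groups on the ring. For the measured compounds named here, no measured step tells what the two methyl groups do. The expectation is therefore a number well above that of compound 3, leaning toward compound 1, with wide uncertainty on the methyl contribution. Compound 4 is expected to come in at 150 nM, between 40 nM and 500 nM, which is an estimated step of a 21-fold higher number from compound 3 to compound 4 (1.33 log units; beyond the scatter) from compound 3 to compound 4, resting on a 50-fold lower number from compound 1 to compound 3 (1.70 log units; beyond the scatter).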

Compound 4, half-maximal inhibitory concentration: 120 nM
Estimate against measurement, compound 4: 1.3-fold (0.10 log units) above; the range from low to high includes it.
By their numbers in this assay, from the lowest: compound 3; then compound 2; then compound 4; then compound 1.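

In this assay, the first measured effect of adding two methyl groups to the hydroxyl-bearing ring at this nitrogen is a 2.9-fold lower number from compound 1 to compound 4 (0.46 log units; beyond the scatter) for the change to 4-hydroxy-3,3-dimethylcyclohexyl, so 4-hydroxycyclohexyl can be improved without removing its hydroxyl. That gain does not match the extended (4-hydroxycyclohexyl)methyl group, as a 2.4-fold higher number from compound 2 to compound 4 (0.38 log units; beyond the scatter) shows, and it falls far short of the carbamoyl group, with a 17-fold higher number from compound 3 to compound 4 (1.23 log units; beyond the scatter) despite equal counts of heavy atoms, hydrogen-bond donors and hydrogen-bond acceptors in the two groups, so those counts alone do not set the number in this small set. No supporting measurement among the data shown gives a reason for any of these steps.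

For the compounds shown here, whether 4-carbamoyl-3,3-dimethylcyclohexyl would keep, improve or lose the standing of compound 3 remains open, since the methyl change is seen only on a hydroxyl-bearing ring. Also open, from the compounds shown here alone, is where a 4-aminocyclohexyl or 4-carboxycyclohexyl group would fall relative to the hydroxyl and carbamoyl groups on the shared core.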